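The source may hold more compounds than are shown below. What is called first, only, known or untested is meant among the compounds shown, and "the series" means these compounds.

Measured compounds: compound 1 `O=C(O)C[C@H](O)C[C@H](O)CCn1c(C(F)(F)F)nc(-c2ccc(C(F)(F)F)cc2)c1-c1ccc(F)cc1` with 200 nM; compound 2 `Cc1cc(-c2nc(C(F)(F)F)n(CC[C@@H](O)C[C@@H](O)CC(=O)O)c2-c2ccc(F)cc2)cc(C)c1F` with 32 nM; compound 3 `O=C(O)C[C@H](O)C[C@H](O)CCn1c(C(F)(F)F)nc(-c2ccc(F)cc2)c1-c1ccccc1` with 201 nM.

These three share one core and differ only in the aromatic ring attached to it. In an assay on microsomes from liver for inhibition of 3-hydroxy-3-methylglutaryl-coenzyme A reductase (Rattus norvegicus) (on this read-out higher numbers stand for weaker inhibition and lower numbers for stronger inhibition), compound 3 gives the highest of the three numbers, though its value and that of compound 1 lie within the scatter of each other, while compound 2 lies clearly lower. Going by the values given here, the one change that has been measured, a 6.3-fold lower number from compound 1 to compound 2 (0.80 log units; beyond the scatter), is the only step that touches this same ring, and it shows that swapping the groups on it can shift the number beyond the scatter.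

Compound 4 `Cc1cccc(-c2c(-c3ccc(F)cc3)nc(C(F)(F)F)n2CC[C@@H](O)C[C@@H](O)CC(=O)O)c1` is reached from compound 3 by methyl in place of hydrogen on an aromatic carbon, giving a 3-methylphenyl ring. Because compound 2, which carries methyl groups on this ring, gives 32 nM, a modest move toward lower numbers is expected for compound 4, smaller than the step to compound 2 since only one methyl enters. Compound 4 is therefore estimated at 110 nM, within 45 nM to 260 nM, an expected step of a 1.8-fold lower number from compound 3 to compound 4 (0.26 log units; within the scatter).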

Compound 4, half-maximal inhibitory concentration: 74 nM
Compound 4: the middle estimate sits 1.5-fold (0.17 log units) above what was measured, within the range that was stated.
By their numbers in this assay, from the lowest: compound 2; then compound 4; then compounds 1 and 3 (each within the scatter of the next).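

In this assay methyl in place of hydrogen on an aromatic carbon gives a 2.7-fold lower number from compound 3 to compound 4 (0.43 log units; beyond the scatter) so a single added carbon, meta to a large group, is enough to move the number beyond the scatter. The earlier step on this ring exchanged one substituted ring for another, with several groups changing at once, whereas here phenyl becomes 3-methylphenyl and nothing else differs. Nothing measured here gives a reason for this shift.

The compounds shown leave open whether a longer chain such as ethyl, or a methoxy group or an amine, would move the number further if it stood in place of this methyl. They also leave open whether the methyl step keeps its size on a ring that already carries a chlorine atom.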